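This account rests on a few compounds, and the source may have more. Where it says the series, first, only, none or still open, it means among the compounds named here.

Among the measured compounds shown here, in a functional assay on cells (Tumor Cell line, Homo sapiens) for antiproliferative activity (a higher number here means a weaker inhibitor of growth, a lower number a stronger inhibitor of growth), compound 1 `Cc1ccnc2nc(-c3cccc(Cl)c3)cc(O)c12` gives 158 nM and compound 2 `Cc1cc(C)c2c(O)cc(-c3cccc(F)c3)nc2n1` gives 85.1 nM, so compound 2 stands within the scatter of the only other measured compound. For the measured compounds named here, these two differ in more than one place, and the series has no measured step that isolates a single change. Compound 3 `Cc1cc(C)c2c(O)cc(-c3cccc(Cl)c3)nc2n1` departs from compound 2 by one change: chloro in place of fluoro on an aromatic carbon. Going by the values given here, compound 1 also carries chloro, and its 158 nM offers the only indirect guide, since it stays within the scatter of compound 2 at 85.1 nM. No change beyond the scatter is therefore expected in this assay. The estimated move is a 1.2-fold higher number from compound 2 to compound 3 (0.07 log units; within the scatter), with its direction uncertain. The expected value for compound 3 is 100 nM, with an estimated range of 40 nM to 250 nM.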

Compound 3, concentration for 50% growth inhibition: 347 nM
The estimate for compound 3 lay 3.5-fold (0.54 log units) below the measured number; the measured number lies above the stated range.
By their numbers in this assay, from the lowest: compounds 2 and 1 (each within the scatter of the next); then compound 3.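

In this assay, chloro in place of fluoro on an aromatic carbon, meta to a large group, gives the series its first single-change reading at this position, and the step is a 4.1-fold higher number from compound 2 to compound 3 (0.61 log units; beyond the scatter). The second single change, methyl in place of hydrogen on an aromatic carbon, also leads to a higher number, a 2.2-fold higher number from compound 1 to compound 3 (0.34 log units; beyond the scatter), so compound 3 stands above both of its single-change neighbours. Nothing measured on hand accounts for either step.

As far as these compounds go, only fluoro and chloro stand at this position, so how a methoxy group, a nitrile or an amine there would read in this assay remains open. Also open, from the compounds shown here alone, is whether the step from fluoro to chloro has the same size on the core of compound 1.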